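The source may hold more compounds than are shown below. What is called first, only, known or untested is meant among the compounds shown, and "the series" means these compounds.

Measured so far:

Compound 1, `CC(C)(C)Nc1nc2cc(-c3ccc(Br)cc3)sc2c(=O)[nH]1`, gives 1400 nM in an ADME assay on HepG2 cells (Homo sapiens) for cytotoxicity, read by MTT assay, with a stated time of 72 h; on this read-out lower numbers stand for higher toxicity in this test and higher numbers for lower toxicity in this test.
Compound 2, `CC(C)Nc1nc2cc(-c3ccc(Br)cc3)sc2c(=O)[nH]1`, gives 13400 nM in this assay.
Compound 3, `Cc1ccc(-c2csc3c(=O)[nH]c(NC(C)(C)C)nc23)cc1`, gives 1400 nM in this assay.

Compound 1 and compound 2 differ in one place: hydrogen in place of methyl on a saturated chain carbon bound to a nitrogen on an aromatic ring and two saturated chain carbons. That change made a step of a 9.6-fold higher number from compound 1 to compound 2 (0.98 log units; beyond the scatter), so the smaller group went with a noticeably less toxic reading. Compound 3 carries a different core from compound 1; the difference between the two cores is not broken down here. In this assay compound 3 sits level with compound 1, the two numbers falling within the usual scatter of each other.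

Compound 4, `Cc1ccc(-c2csc3c(=O)[nH]c(NC(C)C)nc23)cc1`, is related to compound 3 by the same change at the same place: hydrogen in place of methyl on a saturated chain carbon bound to a nitrogen on an aromatic ring and two saturated chain carbons. If the change behaves on the core of compound 3 as it did on the core of compound 1, a step of a 9.3-fold higher number from compound 3 to compound 4 (0.97 log units; beyond the scatter) is expected, because a 9.6-fold higher number from compound 1 to compound 2 (0.98 log units; beyond the scatter) was seen before and compound 3 starts from 1400 nM. Compound 4 is therefore estimated at 13000 nM, with a likely range from 5000 nM to 32000 nM.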

Compound 4, half-maximal cytotoxic concentration: 8800 nM
Estimate against measurement, compound 4: 1.5-fold (0.17 log units) above, and the stated range covers the measured number.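

Replacing tert-butyl with isopropyl on the second core gave a 6.3-fold higher number from compound 3 to compound 4 (0.80 log units; beyond the scatter) in this assay and so, as on the first core, a less toxic reading. Set beside the earlier step, the two sizes agree: the same change on two cores in this assay, a 9.6-fold higher number (0.98 log units; beyond the scatter) from compound 1 to compound 2 and a 6.3-fold higher number (0.80 log units; beyond the scatter) from compound 3 to compound 4, 1.5-fold (0.18 log units) apart, within the scatter of two such steps. Within these four compounds, then, the change carried from one core to the other in both direction and size, but this rests on only two pairs and shows neither that it would hold on further cores or in other tests nor why the reading moves.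

The compounds shown leave open how the reading would respond to other groups at this place, such as an ethyl group, a cyclopropyl ring or a plain amine with no chain at all. They also leave open whether the toxicity reading keeps falling steadily as the chain shrinks, or whether the gap between tert-butyl and isopropyl is a special case.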